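Swapping 4-methylpiperidin-1-yl for (3-chlorophenyl)amino on the shared core

This account rests on a few compounds, and the source may have more. Where it says the series, first, only, none or still open, it means among the compounds named here.

Measured in a functional assay on A-375 cells (Homo sapiens) for antiproliferative activity, read by CCK-8 assay, with a stated time of 72 h; a lower number here means a stronger inhibitor, a higher number a weaker inhibitor:
compound 1 `Cc1ccc(Nc2nc(Cl)nc3c2ncn3Cc2ccc(C(=O)Nc3ccccc3N)cc2)cc1`: 470 nM
compound 2 `CC1CCN(c2nc(Cl)nc3c2ncn3Cc2ccc(C(=O)Nc3ccccc3N)cc2)CC1`: 4240 nM

Of these two, compound 2 gives the higher number, 4240 nM in this assay, and so is the weaker inhibitor. The next compound, compound 3 `Nc1ccccc1NC(=O)c1ccc(Cn2cnc3c(Nc4cccc(Cl)c4)nc(Cl)nc32)cc1`, differs from it as follows: (3-chlorophenyl)amino in place of 4-methylpiperidin-1-yl on an aromatic carbon. In words, (3-chlorophenyl)amino takes the place of 4-methylpiperidin-1-yl on an aromatic carbon, next to the ring nitrogen.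

Among the measured compounds shown here, only one measured step bears on this change: a 9.0-fold higher number from compound 1 to compound 2 (0.96 log units; beyond the scatter). That step put 4-methylpiperidin-1-yl in place of (4-methylphenyl)amino, so the new change runs the opposite way, back to a substituted phenylamino group. For the measured compounds named here, no measurement yet compares (3-chlorophenyl)amino with (4-methylphenyl)amino, which leaves real uncertainty. Compound 1, at 470 nM, is therefore the best guide, and a drop of similar size to the measured step is expected. The expected change is an 8.5-fold lower number from compound 2 to compound 3 (0.93 log units; beyond the scatter). For compound 3 the estimated value is 500 nM, with an expected range from 150 nM to 1600 nM.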

Compound 3, half-maximal inhibitory concentration: 6080 nM
Compound 3: the middle estimate sits 12-fold (1.08 log units) below what was measured; the whole stated range lies below it.
By their numbers in this assay, from the lowest: compound 1; then compounds 2 and 3 (each within the scatter of the next).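

In this assay, a phenylamino group at this position did not by itself carry the better value of compound 1: with (3-chlorophenyl)amino in place of 4-methylpiperidin-1-yl, the result was a 1.4-fold higher number from compound 2 to compound 3 (0.16 log units; within the scatter), so these two groups could not be told apart here. The change within the phenylamino series mattered far more, with a 13-fold higher number from compound 1 to compound 3 (1.11 log units; beyond the scatter), showing that the outcome at this position depended on what the phenyl ring carried and not only on the presence of the aromatic ring and its nitrogen link. Nothing available accounts for either step.

The step between compound 1 and compound 3 alters both the group on the phenyl ring and where it sits, so the compounds shown cannot separate the effect of replacing methyl with chloro from the effect of its ring position. On these data alone, it also remains open how a plain phenylamino group, or a phenylamino group carrying a fluoro or methoxy group, would compare at this position.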